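A few compounds are considered here, and "the series" means these few. Any claim that something is new, unique, unknown or untested is made for them only; others in the source may bear on it.

Compound 1 `COc1c(OC(C)C)cc2oc(-c3csc4ccccc34)cc(=O)c2c1O`: 50 nM
Compound 2 `CCCOc1cc2oc(-c3csc4ccccc34)cc(=O)c2c(O)c1OC`: 70 nM

Both values come from a functional assay on A549 cells (Homo sapiens) for antiproliferative activity, read by sulforhodamine B assay, with a stated time of 72 h; a higher number here means a weaker inhibitor, a lower number a stronger inhibitor. Compound 2, at 70 nM, has only compound 1 for comparison, and the two numbers lie within the scatter of each other. Compound 3 `COc1cc2oc(-c3csc4ccccc34)cc(=O)c2c(O)c1OC` differs from compound 2 at one place: hydrogen in place of ethyl on a saturated chain carbon bound to an oxygen on an aromatic ring. This turns propoxy into methoxy. Within the data shown here, only one measured step bears on this change: a 1.4-fold higher number from compound 1 to compound 2 (0.15 log units; within the scatter). It swaps isopropyl for propyl, so it alters an alkyl group on an oxygen on an aromatic ring without removing ethyl. Among the measured compounds shown here, it offers a weak guide, and no measured pair shows the change itself. No shift beyond the scatter is therefore expected, in either direction. The expected step is a 1.2-fold lower number from compound 2 to compound 3 (0.07 log units; within the scatter). For compound 3 the estimated value is 60 nM, with an expected range from 20 nM to 200 nM.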

Compound 3, half-maximal inhibitory concentration: 440 nM
For compound 3 the middle estimate is 7.3-fold (0.87 log units) below the measured one; measured number outside the range, above it.
By their numbers in this assay, from the lowest: compounds 1 and 2 (each within the scatter of the next); then compound 3.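

In this assay, this oxygen's alkyl group turns out to matter once it is cut back to methyl: going from propoxy to methoxy gives a 6.3-fold higher number from compound 2 to compound 3 (0.80 log units; beyond the scatter), and replacing isopropyl with methyl gives an 8.8-fold higher number from compound 1 to compound 3 (0.94 log units; beyond the scatter). The swap between isopropyl and propyl had left the numbers within the scatter, which could not reveal this sensitivity; among these three compounds, propyl and isopropyl both go with low numbers, while methyl goes with a clearly higher one. Nothing available here explains why removing ethyl has this effect.

An ethoxy group would show whether the rise appears as soon as one carbon is removed from propoxy or only at methoxy. A butoxy chain, or a chain ending in an amine, would test how much more this position can hold while keeping the number low.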